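Moving a Ring Nitrogen in a CXCR3 Inhibitor Series

This account rests on a few compounds, and the source may have more. Where it says the series, first, only, none or still open, it means among the compounds named here.

Measured so far:
compound 1, `CCOc1ncc(-c2nc(C(F)(F)F)sc2N2CCN(C(=O)Cn3cnc4ccccc43)[C@H](C)C2)cn1`, 192 nM
compound 2, `CCOc1ncc(-c2nc(C(F)(F)F)sc2N2CCN(C(=O)Cn3ccc4cccnc43)[C@H](C)C2)cn1`, 47 nM

In an assay on blood for inhibition of C-X-C chemokine receptor type 3 (Homo sapiens), with a stated time of 30 min (a higher number here means a weaker inhibitor, a lower number a stronger inhibitor), compound 1 gives 192 nM, while compound 2 gives 47 nM. Among the compounds with values here, compound 2 therefore stands at the lowest number of the two, and the step of a 4.1-fold lower number from compound 1 to compound 2 (0.61 log units; beyond the scatter) is the only measured comparison in this set.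

Compound 3, `CCOc1ncc(-c2nc(C(F)(F)F)sc2N2CCN(C(=O)Cn3ccc4cnccc43)[C@H](C)C2)cn1`, has not been measured yet. It differs from compound 2 only in the arrangement of the same atoms: a group of 9 heavy atoms (7 carbon, 2 nitrogen; one five-membered aromatic ring with 1 hetero atom, one six-membered aromatic ring with 1 hetero atom) in place of a group of 9 heavy atoms (7 carbon, 2 nitrogen; one five-membered aromatic ring with 1 hetero atom, one six-membered aromatic ring with 1 hetero atom), on a saturated chain carbon bound to a carbonyl carbon. Both groups carry the same counts of carbon and nitrogen, the same ring sizes and the same number of hydrogen-bond acceptors; what changes is where the ring nitrogen sits within the bicyclic group.

Within the data shown here, the one measured step bears on it only loosely. That step, from compound 1 to compound 2, changed the ring type as well as the nitrogen arrangement and was modest in size. The change from compound 2 to compound 3 is smaller in kind, so the expected step of a 1.6-fold higher number from compound 2 to compound 3 (0.20 log units; within the scatter) is estimated to stay near the scatter, with a slight lean toward a higher number. For compound 3 in this assay the expected value is 75 nM, estimated to fall between 25 nM and 230 nM.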

Compound 3, half-maximal inhibitory concentration: 25 nM
Compound 3: the middle estimate sits 3.0-fold (0.48 log units) above what was measured, within the range that was stated.
By their numbers in this assay, from the lowest: compounds 3 and 2 (each within the scatter of the next); then compound 1.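

Compound 2 and compound 3 carry the same atoms in the bicyclic group, and in this assay the result is a 1.9-fold lower number from compound 2 to compound 3 (0.27 log units; within the scatter), so these two placements of the ring nitrogen cannot be told apart here. The wider comparison, a 7.7-fold lower number from compound 1 to compound 3 (0.89 log units; beyond the scatter), lies beyond the scatter, as does the step from compound 1 to compound 2; among these three compounds, then, both groups with one hetero atom in each ring give a lower number than the group with two hetero atoms in the five-membered ring and a six-membered ring of carbon only. Nothing measured here explains either the gap to compound 1 or the closeness of compound 2 and compound 3.

Still open, on these data alone, is whether a nitrogen in the six-membered ring matters at all, a question that a group with a five-membered aromatic ring with 1 hetero atom and a six-membered aromatic ring of carbon only could address. It is also unknown how the number would respond to a substituent on the bicyclic group, such as a methoxy group or a chlorine atom.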